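This account rests on a few compounds, and the source may have more. Where it says the series, first, only, none or still open, it means among the compounds named here.

Working notes on the series. Within the data shown here, compound 1 `O=C(COc1ccc(C(=O)/C=C/c2cccc(Br)c2)cc1)N[C@H]1CCOC1=O` is the reference point of the set; in a functional assay on PC-3 cells (Homo sapiens) for antiproliferative activity, read by MTT assay, with a stated time of 72 h (a higher number here means a weaker inhibitor, a lower number a stronger inhibitor), compound 1 gives 7890 nM, which is the only numerical value available so far. Compound 2 `Cc1cc(Cl)ccc1NCC(=O)N[C@H]1CCOC1=O` carries a different arm on the shared core. In this assay compound 2 reaches only the limit of the assay, > 64000 nM, a limit and not a number (the limit of > 64000 nM in this assay, at which 1 of the 2 values shown sits). Compound 1 therefore stands alone as the sole numbered point, with compound 2 sitting at the limit. Compound 3 `O=C(COc1ccc(C(=O)/C=C/c2ccccc2)cc1)N[C@H]1CCOC1=O` is the next step from compound 1: hydrogen in place of bromo on an aromatic carbon, read one bond further out as 3-bromophenyl to phenyl. Among the measured compounds shown here, no measured step between compounds yet shows what such a change does here. A modest weakening is expected from compound 1 to compound 3, a 1.6-fold higher number from compound 1 to compound 3 (0.22 log units; within the scatter), close to the edge of the scatter. Compound 3 is estimated at 13000 nM, with a range of 4500 nM to 40000 nM.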

Compound 3, half-maximal inhibitory concentration: 56800 nM
The estimate for compound 3 lay 4.4-fold (0.64 log units) below the measured number; the measured number lies above the stated range.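

In this assay, among these compounds, hydrogen in place of bromo gives a 7.2-fold higher number from compound 1 to compound 3 (0.86 log units; beyond the scatter) and this is the first measured step, on an aromatic carbon meta to a large group. The step shows that the readout responds to this one atom, so the number of compound 1 depends on the 3-bromophenyl end of the arm and not on the rest of the structure alone. Compound 2 remains a limit of the assay and not a number: the limit of > 64000 nM in this assay, at which 1 of the 3 values shown sits.

On these data alone, only bromo and hydrogen are compared at this place, so it stays open whether chloro, methoxy or trifluoromethyl there would match bromo or go beyond it. Also open, as far as these compounds go, is how an amine or a carboxylic acid on the same ring would read, and whether bromo at other places on that ring would give the same step.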